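Swapping one ring where every reading is a limit

A few compounds are considered here, and "the series" means these few. Any claim that something is new, unique, unknown or untested is made for them only; others in the source may bear on it.

Compound 1 `O=c1nc(-c2ccccc2)c2cc(-c3cccnc3)ccc2[nH]1` gives > 50000 nM as a limit
Compound 2 `Cc1ccncc1-c1ccc2[nH]c(=O)nc(-c3ccccc3)c2c1` gives > 50000 nM as a limit
Compound 3 `O=c1nc(-c2ccccc2)c2cc(-c3cccc(F)c3)ccc2[nH]1` gives > 50000 nM as a limit

These readings come from an ADME assay on THP-1 cells (Homo sapiens) for cytotoxicity, read by MTT assay, with a stated time of 72 h (a lower number here means that less compound is needed, a higher number that more compound is needed for the effect), and none of them is an exact number. Compound 3 shares the limit of > 50000 nM in this assay, at which 3 of the 3 values shown sit, and so cannot be ranked against the others. Compound 4 `Cn1cc(-c2ccc3[nH]c(=O)nc(-c4ccccc4)c3c2)cn1` carries 1-methyl-1H-pyrazol-4-yl in place of 3-fluorophenyl on an aromatic carbon, and 1-methyl-1H-pyrazol-4-yl in place of 3-fluorophenyl on an aromatic carbon gives the count of that difference. The closest measured swaps are a step that the two limits leave unreadable from compound 1 to compound 3 and a step that the two limits leave unreadable from compound 2 to compound 3 and neither offers a size to carry over. No step beyond the usual scatter is therefore expected in either direction, so the expected change is a number no higher from compound 3 to compound 4 (the limit leaves the size open) and no more. Compound 4 is estimated at 50000 nM with a range of 20000 nM to 100000 nM and will most likely read as a limit again.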

Compound 4, half-maximal effective concentration: > 50000 nM
Compound 4: only a limit was reported (the forecaster's own chance of this, stated with the estimate: 80%); the middle value lies on the limit itself.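

Compound 4, like compound 1, compound 2 and compound 3, gives only a limit in this assay, so no step among these compounds can be read: the limit of > 50000 nM in this assay, at which 4 of the 4 values shown sit.

The compounds shown leave open whether these ring swaps change the concentration at which the cells are affected, and by how much.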